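Series notes: aminoalkyl group in place of acetyl

A few compounds are considered here, and "the series" means these few. Any claim that something is new, unique, unknown or untested is made for them only; others in the source may bear on it.

Measured so far in an assay on COS-7 cells for inhibition of patatin-like phospholipase domain-containing protein 2 (Mus musculus), tested at 200 uM; on this read-out higher numbers stand for more inhibition at the one concentration tested (going by the name of the read-out) and lower numbers for less inhibition:
compound 1 `CCOC(=O)c1cccc(-c2ccc(N(C)C)cc2)c1` gives 87%
compound 2 `CCOC(=O)c1cccc(-c2ccc(C(C)=O)cc2)c1` gives 36%

Going by the values given here, compound 2 stands lowest of the two numbers in this assay, with compound 1 as its only neighbour. Among the compounds with values here, the single recorded step between them, a number 51 percentage points lower from compound 1 to compound 2 (beyond the scatter), lies beyond the scatter and is large.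

Compound 3 `CCOC(=O)c1cccc(-c2ccc(C(C)N(C)C)cc2)c1` differs from compound 2 by 1-(dimethylamino)ethyl in place of acetyl on an aromatic carbon. Within the data shown here, the only measured step that bears on this change is a number 51 percentage points lower from compound 1 to compound 2 (beyond the scatter), where acetyl took the place of dimethylamino and the reading fell sharply. Compound 3 brings a dimethylamino back, now as part of a 1-(dimethylamino)ethyl group rather than attached directly to the ring, so a rise in this assay is expected, though not a full return to the level of compound 1 is assumed. Compound 3 is therefore estimated at 65%, with a range from 40% to 85%. The expected step is a number 29 percentage points higher from compound 2 to compound 3 (beyond the scatter).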

Compound 3, a percentage reported as inhibition, at one concentration (the size of the read-out at that concentration, not a potency): 50%
Compound 3: the middle estimate sits 15 percentage points above what was measured; the range from low to high includes it.
By their numbers in this assay, from the lowest: compound 2; then compound 3; then compound 1.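

In this assay, 1-(dimethylamino)ethyl in place of acetyl on an aromatic carbon, para to a large group, brings only a modest recovery: a number 14 percentage points higher from compound 2 to compound 3 (beyond the scatter). Set against dimethylamino at the same place, the same group gives a large loss, a number 37 percentage points lower from compound 1 to compound 3 (beyond the scatter), so a dimethylamino unit within the substituent is not enough to restore the reading of compound 1. Nothing available explains either step.

Still open, going by these compounds, is whether the loss follows the branching methyl of 1-(dimethylamino)ethyl or the carbon chain that carries the amine, a question that dimethylaminomethyl and 2-(dimethylamino)ethyl groups at this place could separate. The compounds shown also leave open how a primary amine or a carboxylic acid here would read on this scale.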